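The source may report more compounds than this note shows. Statements on the series, on what has been measured and on what is new or still open speak of the compounds shown alone.

Working notes on the series.

Compound 1 `O=S(=O)(/C=C/c1ccc(Cl)cc1Cl)Cc1ccc(Nc2ncnc3ccccc23)cc1` carries a 2,4-dichlorophenyl on the chain; in a functional assay on OVCAR-8 cells (Homo sapiens) (a lower number here means a stronger inhibitor of growth, a higher number a weaker inhibitor of growth), compound 1 gives 4000 nM. Compound 2 `O=S(=O)(/C=C/c1ccc(C(F)(F)F)cc1F)Cc1ccc(Nc2ncnc3ccccc23)cc1` differs from compound 1 by 2-fluoro-4-(trifluoromethyl)phenyl in place of 2,4-dichlorophenyl on a double-bonded chain carbon bound to a double-bonded chain carbon, and in this assay compound 2 gives 100000 nM, so the change brings a 25-fold higher number from compound 1 to compound 2 (1.40 log units; beyond the scatter). Compound 3 `O=S(=O)(/C=C/c1ccc(Cl)cc1Cl)Cc1ccc(Nc2ncnc3ccc(Br)cc23)cc1` differs from compound 1 only in the core, by bromo in place of hydrogen on an aromatic carbon; in this assay compound 3 gives 3000 nM, a step of a 1.3-fold lower number from compound 1 to compound 3 (0.12 log units; within the scatter).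

Compound 4 `O=S(=O)(/C=C/c1ccc(C(F)(F)F)cc1F)Cc1ccc(Nc2ncnc3ccc(Br)cc23)cc1` has not yet been measured in this assay. It differs from compound 3 by 2-fluoro-4-(trifluoromethyl)phenyl in place of 2,4-dichlorophenyl on a double-bonded chain carbon bound to a double-bonded chain carbon, and the place is worded the same as for the pair of compound 1 and compound 2, so this is the same change made on the brominated core. Among the measured compounds shown here, with only the one measured example of the change, the expectation rests on compound 1 and compound 2 and their step of a 25-fold higher number from compound 1 to compound 2 (1.40 log units; beyond the scatter), which is expected to carry over to the brominated core in about the same size.

For compound 4 the expected step from compound 3 is a 25-fold higher number from compound 3 to compound 4 (1.40 log units; beyond the scatter), since the core change measured as a 1.3-fold lower number from compound 1 to compound 3 (0.12 log units; within the scatter) gave no sign of altering the series. The estimate for compound 4 in this assay is therefore 75000 nM, expected to lie between 25000 nM and 200000 nM.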

Compound 4, concentration for 50% growth inhibition: 15000 nM
Estimate against measurement, compound 4: 5.0-fold (0.70 log units) above, outside the stated range (below it).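

In this assay, 2-fluoro-4-(trifluoromethyl)phenyl in place of 2,4-dichlorophenyl again gives a higher number on the brominated core, a 5.0-fold higher number from compound 3 to compound 4 (0.70 log units; beyond the scatter), but the size of the step does not carry over: the same change on two cores in this assay, a 25-fold higher number (1.40 log units; beyond the scatter) from compound 1 to compound 2 and a 5.0-fold higher number (0.70 log units; beyond the scatter) from compound 3 to compound 4, 5.0-fold (0.70 log units) apart, beyond the scatter of two such steps. Read the other way, bromo in place of hydrogen brings a 6.7-fold lower number from compound 2 to compound 4 (0.82 log units; beyond the scatter), and this too depends on the group on the chain: the same change on two cores in this assay, a 1.3-fold lower number (0.12 log units; within the scatter) from compound 1 to compound 3 and a 6.7-fold lower number (0.82 log units; beyond the scatter) from compound 2 to compound 4, 5.0-fold (0.70 log units) apart, beyond the scatter of two such steps. So the direction of the chain change carries from one core to the other but its size does not, and these two gaps are one observation from the same four compounds, which shows that the two changes are not independent here but gives neither a general rule nor a cause.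

The compounds shown leave open whether the dependence extends to other groups on the chain, such as a plain phenyl or a methoxyphenyl. They also leave open how the chain change would behave with a methoxy group or an amine in place of bromo on the core.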